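This account rests on a few compounds, and the source may have more. Where it says the series, first, only, none or still open, it means among the compounds named here.

Three related compounds have been measured so far in an ADME assay on microsomes from liver (Homo sapiens) for metabolic stability, read by mass spectrometry, using NADPH, with a stated time of 10 min (on this read-out lower numbers stand for a less stable compound and higher numbers for a more stable compound), and the next one builds on compound 3. Compound 3 `CCCCc1[nH]c(=O)c(-c2nnc(Cc3ccccc3)o2)c(O)c1-c1c(OC)cccc1OC` gives 87% and compound 2 `CCCCc1[nH]c(=O)c(-c2nnc(Cc3cccc(Cl)c3)o2)c(O)c1-c1c(OC)cccc1OC` gives 88% on this scale, so these two stand level within the scatter. Compound 1 `CCCCc1[nH]c(=O)c(-c2n[nH]c(Cc3ccccc3)n2)c(O)c1-c1c(OC)cccc1OC` gives 36% and lies far lower than compound 3.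

Compound 4 `CCCCc1[nH]c(=O)c(-c2nnc(Cc3ccccc3Cl)o2)c(O)c1-c1c(OC)cccc1OC` is compound 3 with a single change chloro in place of hydrogen on an aromatic carbon in which chloro takes the place of hydrogen on an aromatic carbon, ortho to a large group, turning benzyl into 2-chlorobenzyl.

Going by the values given here, one measured step bears on this, with hydrogen in place of chloro on an aromatic carbon: a number 1 percentage points lower from compound 2 to compound 3 (within the scatter) (a small step). The chloro of compound 4 does not stand where the chloro of compound 2 stands, so that step is only a guide. No step beyond the scatter is therefore expected, and no firm direction. The expected step is small: a number 2 percentage points lower from compound 3 to compound 4 (within the scatter) (an estimate). Compound 4 is expected at 85% with an estimated range from 70% to 95% in this read-out.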

Compound 4, percent of the compound remaining: 82%
Estimate against measurement, compound 4: 3 percentage points above; low and high end bracket the measured number.
By their numbers in this assay, from the lowest: compound 1; then compounds 4, 3 and 2 (each within the scatter of the next).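

Benzyl changing to 2-chlorobenzyl gives a number 5 percentage points lower from compound 3 to compound 4 (within the scatter) in this assay, so a chloro at this place, ortho to a large group, leaves the number level with the unsubstituted benzyl group of compound 3. Moving the chloro from 3-chlorophenyl to 2-chlorophenyl gives a number 6 percentage points lower from compound 2 to compound 4 (within the scatter) and so does not separate the two placements either: on this read-out, compounds 2, 3 and 4 form one level group, whichever of these forms the benzyl ring takes. No measurement at hand gives a reason for this result.

Still open, as far as these compounds go, is whether a methoxy group, an amine or a carboxylic acid at this same place would stay level with compound 3 as chloro does. From the compounds shown here alone, it is also open whether a longer chain in place of the butyl chain would keep the number this high.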